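This account rests on a few compounds, and the source may have more. Where it says the series, first, only, none or still open, it means among the compounds named here.

Compound 1 `CCCCCOC(=O)NS(=O)(=O)c1sc(CC(C)C)cc1-c1cccc(Cn2ccnc2)c1` gives 0.108 h in an ADME assay on microsomes from liver (Homo sapiens) for metabolic stability, read by LC-MS, using NADPH, tested at 1 uM; a lower number here means that the compound disappears faster, a higher number that the compound lasts longer.
Compound 2 `CC(C)Cc1cc(-c2cccc(Cn3ccnc3)c2)c(S(=O)(=O)NC(=O)C2CC2)s1` gives 0.333 h in this assay.

Compound 1 stands lowest of the two numbers; its nearest neighbour is compound 2, and the step of a 3.1-fold higher number from compound 1 to compound 2 (0.49 log units; beyond the scatter) is modest. Compound 3 `CCCCCC(=O)NS(=O)(=O)c1sc(CC(C)C)cc1-c1cccc(Cn2ccnc2)c1` differs from compound 1 by pentyl in place of pentyloxy on a carbonyl carbon. Among the measured compounds shown here, the only measured step that bears on this change is the one from compound 1 to compound 2, where a group on the same carbonyl carbon was exchanged, with the result a 3.1-fold higher number from compound 1 to compound 2 (0.49 log units; beyond the scatter). A similar-sized increase in this assay is therefore expected for compound 3, as a 2.0-fold higher number from compound 1 to compound 3 (0.31 log units; beyond the scatter). The estimate for compound 3 is 0.22 h, within 0.09 h to 0.55 h.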

Compound 3, half-life: 0.117 h
Beside the measured number, compound 3's estimate is 1.9-fold (0.27 log units) above it; low and high end bracket the measured number.
By their numbers in this assay, from the lowest: compounds 1 and 3 (each within the scatter of the next); then compound 2.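

Taking the oxygen out of the pentyloxy group, so that pentyl sits on the carbonyl carbon, leaves this assay unmoved (a 1.1-fold higher number from compound 1 to compound 3 (0.03 log units; within the scatter)). Pentyl in place of cyclopropyl on the same carbon gives a clear drop (a 2.8-fold lower number from compound 2 to compound 3 (0.45 log units; beyond the scatter)), so losing the oxygen alone does not reproduce the rise seen with cyclopropyl. No measurement shown explains this difference.

The compounds shown leave open whether the rise follows the ring or the shorter group, which a methyl, an ethyl or a cyclobutyl on this carbonyl carbon could separate.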